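Methoxy on the core of compound 2: an estimate

A few compounds are considered here, and "the series" means these few. Any claim that something is new, unique, unknown or untested is made for them only; others in the source may bear on it.

Measured compounds:
- compound 1 `FC(F)(F)c1ccccc1-c1nc(NCc2ccc(-c3ccncc3)cc2)c2ccccc2n1`: 1900 nM
- compound 2 `CC(C)c1ccccc1-c1nccc(NCc2ccc(-c3cccnc3)cc2)n1`: 150 nM
- compound 3 `Cc1cc(NCc2ccc(-c3cccnc3)cc2)nc(-c2ccccc2C(C)C)n1`: 210 nM

In an assay on a protein complex for inhibition of ubiquitin carboxyl-terminal hydrolase 1/WD repeat-containing protein 48 (Homo sapiens), read by fluorescence (a lower number here means a stronger inhibitor, a higher number a weaker inhibitor), compound 2 gives the lowest of the three numbers shown. Compound 3 lies nearest, and the step of a 1.4-fold higher number from compound 2 to compound 3 (0.15 log units; within the scatter) is within the scatter, so the two cannot be ordered. Compound 1, built on a different core, stands furthest away; the gap between compound 2 and compound 1 is beyond the scatter, with compound 1 the weaker of the two.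

Compound 4 `COc1cnc(-c2ccccc2C(C)C)nc1NCc1ccc(-c2cccnc2)cc1` has not yet been measured. It differs from compound 2 by methoxy in place of hydrogen on an aromatic carbon. For the measured compounds named here, the only measured step that bears on this change is the one from compound 2 to compound 3, where a small group was also added to the shared core and the number moved by a 1.4-fold higher number from compound 2 to compound 3 (0.15 log units; within the scatter), within the scatter. The methoxy group sits at a different carbon of the core, so that step is a loose guide only. Going by the values given here, no other pair separates the effect of such a substituent.

For compound 4 the expected result in this assay is 240 nM, with a range from 90 nM to 700 nM. The expected step is a 1.6-fold higher number from compound 2 to compound 4 (0.20 log units; within the scatter), not beyond the scatter, because a 1.4-fold higher number from compound 2 to compound 3 (0.15 log units; within the scatter) showed a comparable addition leaving the number essentially unchanged.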

Compound 4, half-maximal inhibitory concentration: 70 nM
The estimate for compound 4 lay 3.4-fold (0.54 log units) above the measured number; measured number below the stated range.
By their numbers in this assay, from the lowest: compound 4; then compounds 2 and 3 (each within the scatter of the next); then compound 1.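

In this assay, methoxy in place of hydrogen on this aromatic carbon, ortho to a large group and para to a 2-isopropylphenyl group, gives a 2.1-fold lower number from compound 2 to compound 4 (0.33 log units; beyond the scatter). The step is modest, but it shows that this carbon of the shared core can carry a group larger than hydrogen while the number goes down, not up. The one earlier step on this core, a 1.4-fold higher number from compound 2 to compound 3 (0.15 log units; within the scatter), came from methyl on a different carbon and stayed within the scatter, so it had not shown that a substituent on the core could move the number at all. Nothing among the data shown accounts for the lower number of compound 4.

With a single substituent at this carbon, the compounds shown leave open whether the step belongs to methoxy in particular, or whether an ethoxy, a hydroxyl, a fluorine or an amine there would go the same way. They also leave open whether methoxy at this carbon and the methyl of compound 3 would add up when both stand on the same core.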